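Geometry change at the exocyclic double bond of compound 1

The source may report more compounds than this note shows. Statements on the series, on what has been measured and on what is new or still open speak of the compounds shown alone.

For the measured compounds named here, compound 1, `CCN(CC)CCCn1c(=O)/c(=C/c2ccccc2O)s/c1=C1/C(=O)Nc2ccc(C)cc21`, is the weaker of the two compounds measured so far in a functional assay on K562/Adr cells (Homo sapiens) for cytotoxicity, read by sulforhodamine B assay, with a stated time of 48 h (on this read-out higher numbers stand for weaker inhibition and lower numbers for stronger inhibition), where compound 1 gives 30600 nM. Compound 2, `CCN(CC)CCCn1c(=O)/c(=C/c2ccc(F)c(F)c2)s/c1=C1/C(=O)Nc2ccc(F)cc21`, carries different ring substituents and in this assay compound 2 gives 6480 nM; the gap between the two values lies beyond the scatter, so the ordering holds. Going by the values given here, no pair of measured compounds differs in a single place, so no measured step is available as a guide.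

Compound 3, `CCN(CC)CCCn1c(=O)/c(=C/c2ccccc2O)s/c1=C1\C(=O)Nc2ccc(C)cc21`, is the next compound to be run. Against compound 1 the change is the two compounds have the same atoms and bonds and differ only in configuration as drawn: 1 of 2 stereo elements differ; a double bond is drawn E in compound 1 and Z in compound 3. The two compounds have the same atoms and bonds and differ only in configuration as drawn; a double bond is drawn E in compound 1 and Z in compound 3.

Among the compounds with values here, with no measured geometric pair, the direction of the step is open; the expected step from compound 1 to compound 3 is a 1.2-fold lower number from compound 1 to compound 3 (0.09 log units; within the scatter), that is, nothing expected beyond the scatter. Compound 3 is therefore estimated at 25000 nM in this assay, with a range from 8000 nM to 80000 nM.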

Compound 3, half-maximal inhibitory concentration: 30600 nM
The estimate for compound 3 lay 1.2-fold (0.09 log units) below the measured number, within the range that was stated.
By their numbers in this assay, from the lowest: compound 2; then compounds 1 and 3 (each within the scatter of the next).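

In this assay, the series now has its first step that changes one thing only: no change at the digits printed from compound 1 to compound 3 (within the scatter). With the substituents of compound 1, the geometry drawn at this double bond therefore does not separate the two compounds on this read-out. This makes the comparison a clean one for configuration, and the reading applies to this one pair, where the whole change is this: the fact that compounds 1 and 3 differ only in the configuration as drawn

Compound 2 has no geometric partner among the compounds shown, so it is open whether the same holds with its fluorine-bearing rings. Also open, on these data alone, is how a morpholine or piperidine in place of the diethylamino group, or a longer chain leading to that amine, would read in this assay.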